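Ethyl to difluoromethyl: an expected clearance

The compounds below may be only part of what the source reports. "The series", "measured", "known", "first", "only" and "open" are said of these compounds alone.

Measured so far in an ADME assay (Rattus norvegicus) for pharmacokinetics; on this read-out higher numbers stand for fast clearance and lower numbers for slow clearance:
Compound 1 `C=C[C@@H]1C[C@]1(NC(=O)[C@@H]1[C@H](CC)[C@@H]2CN1C(=O)[C@H](C(C)(C)C)NC(=O)O[C@@H]1C[C@H]1CCCCCc1nc3ccc(OC)cc3nc1O2)C(=O)NS(=O)(=O)C1CC1` gives 14.7 mL/min/kg
Compound 2 `CC[C@@H]1[C@@H]2CN(C(=O)[C@H](C(C)(C)C)NC(=O)O[C@@H]3C[C@H]3CCCCCc3nc4ccc(OC)cc4nc3O2)[C@@H]1C(=O)N[C@]1(C(=O)NS(=O)(=O)C2CC2)C[C@H]1CC` gives 11.2 mL/min/kg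

The values of compound 2 and compound 1 lie within the scatter of each other, so the two cannot be told apart. Compound 3 `CC[C@@H]1[C@@H]2CN(C(=O)[C@H](C(C)(C)C)NC(=O)O[C@@H]3C[C@H]3CCCCCc3nc4ccc(OC)cc4nc3O2)[C@@H]1C(=O)N[C@]1(C(=O)NS(=O)(=O)C2CC2)C[C@H]1C(F)F` keeps the rest of compound 2 and carries difluoromethyl in place of ethyl on a saturated ring carbon of a three-membered non-aromatic ring of carbon only: difluoromethyl in place of ethyl on a saturated ring carbon. Among the compounds with values here, the one measured step, ethyl in place of vinyl on a saturated ring carbon, is a 1.3-fold lower number from compound 1 to compound 2 (0.12 log units; within the scatter) and stays within the scatter. Within the data shown here, no measured compound carries difluoromethyl, so the data offer no direction, and no step beyond the scatter is expected in this assay. The expected result is a 1.0-fold lower number from compound 2 to compound 3 (0.01 log units; within the scatter) in this read-out. For compound 3 the estimated clearance is 11 mL/min/kg, with an expected range of 5.5 mL/min/kg to 22 mL/min/kg.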

Compound 3, clearance: 33.3 mL/min/kg
Beside the measured number, compound 3's estimate is 3.0-fold (0.48 log units) below it; measured number outside the range, above it.
By their numbers in this assay, from the lowest: compounds 2 and 1 (each within the scatter of the next); then compound 3.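

At this place, on a saturated ring carbon of a three-membered non-aromatic ring of carbon only, ethyl and vinyl could not be told apart, so the position had shown no response in this assay until difluoromethyl entered. Difluoromethyl in place of ethyl gives a 3.0-fold higher number from compound 2 to compound 3 (0.47 log units; beyond the scatter), and difluoromethyl in place of vinyl gives a 2.3-fold higher number from compound 1 to compound 3 (0.36 log units; beyond the scatter), so this group stands apart from both hydrocarbon groups on the same core and the read-out does respond to a change here. Nothing available accounts for this rise.

Difluoromethyl is the only fluorine-bearing group at this place among the compounds shown. On these data alone, how fluoromethyl, trifluoromethyl or a longer chain such as propyl would read here remains open, as does whether the same change would give a step of this size on another core.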